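Swapping Chloro for Methoxy on a Weakly Cytotoxic Amide

A few compounds are considered here, and "the series" means these few. Any claim that something is new, unique, unknown or untested is made for them only; others in the source may bear on it.

Three related amides share one core and differ in the group on the outer phenyl ring or in a small change on the far ring system. Compound 1, `COc1ccc(-n2ccc(=O)c(C(=O)Nc3ccc(Oc4ccnc5[nH]ccc45)cc3)n2)cc1`, was tested in a functional assay on HepG2 cells (Homo sapiens) for cytotoxicity, read by MTT assay, with a stated time of 72 h (a lower number here means a stronger inhibitor, a higher number a weaker inhibitor), where compound 1 gives 50800 nM. Compound 2, `Cn1ccc2c(Oc3ccc(NC(=O)c4nn(-c5ccc(Cl)cc5)ccc4=O)cc3)ccnc21`, reaches only a limit in this assay, with compound 2 reported as > 60000 nM. That reading sits at the limit of > 60000 nM in this assay, at which 1 of the 2 values shown sits, so for compound 2 no exact number is known. Compound 3, `COc1ccc(-n2ccc(=O)c(C(=O)Nc3ccc(Oc4ccnc5c4ccn5C)cc3)n2)cc1`, has not yet been measured. It differs from compound 2 in one place: methoxy in place of chloro on an aromatic carbon. For the measured compounds named here, no measured pair differs in only this way, so the size of this step cannot be read from the data. Compound 3 carries the same 4-methoxyphenyl group as compound 1 on a closely related core, and compound 1 gives 50800 nM, which points to a weak result again. Compound 3 is therefore expected to give about 55000 nM, between 25000 nM and 120000 nM. The expected step of an at least 1.0-fold lower number from compound 2 to compound 3 (0.03 log units; that floor lies within the scatter) is accordingly small, not clearly beyond the scatter, and could again end at the limit.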

Compound 3, half-maximal inhibitory concentration: > 60000 nM
Compound 3 gave a limit, no number; the forecaster's own chance of this, stated with the estimate: 50%; middle value at least 1.0-fold (0.03 log units) from the limit.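

On the core that carries the methyl, the position on the outer phenyl ring para to a large group has now held both chloro and methoxy, and neither compound gives an exact number in this assay: the limit of > 60000 nM in this assay, at which 2 of the 3 values shown sit. Compound 2 and compound 3 both end at a limit, so the step between them cannot be read, and the change from 4-chlorophenyl to 4-methoxyphenyl has no measurable size here. With the 4-methoxyphenyl group held constant, methyl in place of hydrogen on the aromatic nitrogen gives an at least 1.1-fold higher number from compound 1 to compound 3 (0.07 log units; that floor lies within the scatter), a floor that does not show this small change to make any real difference, though the true gap could be larger.

The compounds shown leave open whether an amine or a carboxylic acid at this same position on the outer phenyl ring would bring a reading inside the range of this assay. They also leave open how far beyond the limit compound 2 and compound 3 truly lie, and so whether the chloro and methoxy groups differ at all in this assay.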